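Cyclohexylamino in place of arylamino on the shared core

The source may report more compounds than this note shows. Statements on the series, on what has been measured and on what is new or still open speak of the compounds shown alone.

Compound 1, `Cc1ccc(NC2=CC(=O)c3c(nc4n3[C@H]3OC[C@@H](O)[C@H]3OC4)C2=O)cc1`: > 4000 nM
Compound 2, `Cc1ccc(NC2=CC(=O)c3nc4n(c3C2=O)[C@H]2OC[C@@H](O)[C@H]2OC4)cc1`: 3480 nM
Compound 3, `O=C1C=C(N2CCCCC2)C(=O)c2c1nc1n2[C@H]2OC[C@@H](O)[C@H]2OC1`: > 8000 nM

All three were tested in a functional assay on ECa-109 cells for inhibition, with ECa-109 cell line (Homo sapiens) as the target, read by sulforhodamine B assay; on this read-out lower numbers stand for stronger inhibition and higher numbers for weaker inhibition. For compound 1 the result is only a limit of the assay, (the limit of > 4000 nM in this assay, at which 1 of the 3 values shown sits), so no exact number is known for it. Within the data shown here, compound 2 is the one compound with a measured number, 3480 nM. For compound 3 the result is again a limit, (the limit of > 8000 nM in this assay, at which 1 of the 3 values shown sits). Among the measured compounds shown here, the single step between neighbours, an at least 2.2-fold higher number from compound 2 to compound 3 (0.36 log units; beyond the scatter), shows that exchanging the arylamino group for a saturated ring amine made the inhibition weaker, at least modestly, in this assay.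

Compound 4, `O=C1C(NC2CCCCC2)=CC(=O)c2c1nc1n2[C@H]2OC[C@@H](O)[C@H]2OC1`, differs from compound 1 by cyclohexyl in place of 4-methylphenyl on an amine nitrogen. For the measured compounds named here, no measured step makes exactly this change; the step from compound 2 to compound 3 is the nearest, and it points toward weaker inhibition when the aromatic ring on the nitrogen gives way to a saturated one. Since compound 1 already sits at a limit, the expected direction for a step that the limit leaves unreadable from compound 1 to compound 4 is toward a higher number, most likely again reported only as a limit. Compound 4 is therefore estimated at 9000 nM in this assay, within a range from 3000 nM to 30000 nM.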

Compound 4, half-maximal inhibitory concentration: > 16000 nM
Compound 4: no number, only a limit (the forecaster's own chance of this, stated with the estimate: 70%); middle value at least 1.7-fold (0.24 log units) from the limit.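

Compound 1 and compound 4 are both reported only as limits of the assay, so the step between them cannot be read in this assay. The compounds shown leave open whether cyclohexyl in place of 4-methylphenyl on an amine nitrogen changes the inhibition at all, and by how much.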